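Series notes: alkoxy to thioether on the shared core

This account rests on a few compounds, and the source may have more. Where it says the series, first, only, none or still open, it means among the compounds named here.

Compound 3 `CC(C(=O)NCc1ccc(C(C)(C)C)nc1OC1CCCC1)c1ccc(NS(C)(=O)=O)c(F)c1` carries a cyclopentyloxy group on the shared core. Going by the values given here, in an assay on cells for antagonist activity at transient receptor potential cation channel subfamily V member 1 (Homo sapiens), read by FLIPR and calcium flux, with a stated time of 6 min (a higher number here means a weaker inhibitor, a lower number a stronger inhibitor), compound 3 gives 1.5 nM, the highest of the three numbers so far. Compound 2 `CCCCOc1nc(C(C)(C)C)ccc1CNC(=O)C(C)c1ccc(NS(C)(=O)=O)c(F)c1` gives 0.9 nM, and the step of a 1.7-fold higher number from compound 2 to compound 3 (0.22 log units; within the scatter) lies within the scatter. Among the compounds with values here, compound 1 `CC(C(=O)NCc1ccc(C(C)(C)C)nc1N1CCC(Cc2ccccc2)CC1)c1ccc(NS(C)(=O)=O)c(F)c1` gives 0.3 nM, the lowest of the three and beyond the scatter from compound 3; no single-point step connects these two, so their values are only taken as they stand.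

Compound 4 `COc1ccc(CSc2nc(C(C)(C)C)ccc2CNC(=O)C(C)c2ccc(NS(C)(=O)=O)c(F)c2)cc1` differs from compound 3 in one place: (4-methoxybenzyl)sulfanyl in place of cyclopentyloxy on an aromatic carbon. Within the data shown here, the only measured step at this position, a 1.7-fold higher number from compound 2 to compound 3 (0.22 log units; within the scatter), is small, but it exchanges one group on an oxygen for another and covers neither a sulfur link nor an added six-membered aromatic ring, so it is an incomplete guide. The data offer nothing else that bears directly on this change. The expected step for compound 4 is therefore a 1.5-fold lower number from compound 3 to compound 4 (0.18 log units; within the scatter), small and not clearly beyond the scatter, with the range widened downward since compound 1 shows that lower numbers occur in this series. For compound 4 the estimate in this assay is 1 nM, with a range from 0.3 nM to 4 nM.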

Compound 4, inhibition constant: 3.5 nM
Beside the measured number, compound 4's estimate is 3.5-fold (0.54 log units) below it, and the stated range covers the measured number.
By their numbers in this assay, from the lowest: compound 1; then compounds 2 and 3 (each within the scatter of the next); then compound 4.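

Series notes, continued: In this assay the (4-methoxybenzyl)sulfanyl group gives the first steps at this position that lie beyond the scatter, with a 2.3-fold higher number from compound 3 to compound 4 (0.37 log units; beyond the scatter) against cyclopentyloxy and a 3.9-fold higher number from compound 2 to compound 4 (0.59 log units; beyond the scatter) against butoxy, both modest and both toward a higher number. The earlier step between the two groups on an oxygen stayed within the scatter, so this position now shows a measurable response to a change of group, although the sulfur link and the six-membered aromatic ring enter together and these steps cannot assign the rise to either one. Nothing at hand explains the rise.

The compounds shown leave open whether the sulfur link or the added ring carries the step, a question that a butylsulfanyl group and a 4-methoxybenzyloxy group, each changing only one of the two features, would separate. Also open, going by these compounds, is how the nitrogen-linked group of compound 1 relates to these oxygen and sulfur links, since a simple amine such as pyrrolidin-1-yl at this position would give a closer comparison with cyclopentyloxy.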